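Shortening the Alkyne Chain: Effect on Sphingosine Kinase Inhibition in This Assay

The source may report more compounds than this note shows. Statements on the series, on what has been measured and on what is new or still open speak of the compounds shown alone.

Of the compounds shown here, three have been measured in an assay on CHO cells for inhibition of sphingosine kinase 1 (Homo sapiens), tested at 10 uM; on this read-out higher numbers stand for more inhibition at the one concentration tested (going by the name of the read-out) and lower numbers for less inhibition. Compound 1 `CCCCCCCCC#C[C@@H](O)[C@@H](N)CO` gives 13.7%, compound 2 `CCCCCCCCCCCCCC#C[C@@H](O)[C@@H](N)CO` gives 24.4%, and compound 3 `CCCCCCCCCCCCCC#CC(=O)[C@H](CO)NC(=O)OC(C)(C)C` gives 56.9%, the highest of the three. The difference between the core of compound 3 and the core of compound 2 is not broken down here. Compound 2 and compound 1 differ by one change, (hydrogen in place of pentyl on a saturated chain carbon, eight bonds along the chain from a triple-bonded carbon), and that change gave a number 10.7 percentage points lower from compound 2 to compound 1 (beyond the scatter). Compound 4 `CCCCCCCCC#CC(=O)[C@H](CO)NC(=O)OC(C)(C)C` is not yet measured; it stands to compound 3 as compound 1 stands to compound 2, through the same change, (hydrogen in place of pentyl on a saturated chain carbon, eight bonds along the chain from a triple-bonded carbon). In this assay the step is expected to be a number 10.9 percentage points lower from compound 3 to compound 4 (beyond the scatter), an expectation that rests on the measured step of a number 10.7 percentage points lower from compound 2 to compound 1 (beyond the scatter). Compound 4 is therefore estimated at 46%, within a range from 30% to 60%.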

Compound 4, a percentage reported as inhibition, at one concentration (the size of the read-out at that concentration, not a potency): 4.2%
Compound 4: middle estimate off by 41.8 percentage points, on the high side; the measured number lies below the stated range.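

In this assay, hydrogen in place of pentyl gave a number 52.7 percentage points lower from compound 3 to compound 4 (beyond the scatter), so the change did not carry over from one core to the other at a constant size: the same change on two cores in this assay, a number 10.7 percentage points lower (beyond the scatter) from compound 2 to compound 1 and a number 52.7 percentage points lower (beyond the scatter) from compound 3 to compound 4, 42 percentage points apart, beyond the scatter of two such steps

The direction held on both cores, with the number falling each time, but the step on one core did not predict the size of the step on the other. These two pairs do not show which part of the difference between the cores governs the size of the step.

On these data alone, whether a chain of intermediate length would give a gradual or an abrupt fall on either core remains open. Also open, as far as these compounds go, is how the change would behave on a core combining the carbonyl with a free amine, or the hydroxyl with the tert-butyl carbamate.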